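The source may report more compounds than this note shows. Statements on the series, on what has been measured and on what is new or still open speak of the compounds shown alone.

In a physicochemical assay for lipophilicity, read by LC-MS (a higher number here means a more lipophilic compound, a lower number a more polar compound), compound 1 `FC(F)(F)c1nccc(N[C@H]2CC[C@@H](Nc3ccc4nnc(Br)n4n3)CC2)n1` gives 2.9, compound 2 `CSc1nnc2ccc(N[C@H]3CC[C@@H](Nc4ccnc(C(F)(F)F)n4)CC3)nn12` gives 2.8 and compound 3 `Cc1nnc2ccc(N[C@H]3CC[C@@H](Nc4ccnc(C(F)(F)F)n4)CC3)nn12` gives 2.3, the lowest number of the three. Compound 4 `FC(F)(F)c1nccc(N[C@H]2CC[C@@H](Nc3ccc4nnc(C5CC5)n4n3)CC2)n1` keeps the rest of the structure of compound 3 and has cyclopropyl in place of methyl on an aromatic carbon. That carbon belongs to a five-membered aromatic ring with 3 nitrogen, part of a fused or bridged system of two rings, and lies between two ring nitrogen atoms.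

The measured steps that bear on this change are the two that end at methyl on the same carbon: a number 0.60 log units lower from compound 1 to compound 3 (beyond the scatter) and a number 0.50 log units lower from compound 2 to compound 3 (beyond the scatter). The remaining step, a number 0.10 log units lower from compound 1 to compound 2 (within the scatter), separates bromo from methylsulfanyl. Among the measured compounds shown here, no measured compound carries cyclopropyl, so the data give no direct reading for it. Among these three compounds methyl has the lowest number, so moving away from methyl is expected to go the opposite way, by a modest amount of similar size. The expected step is a number 0.50 log units higher from compound 3 to compound 4 (beyond the scatter). For compound 4 the estimated value is 2.8, with an expected range from 2.5 to 3.1.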

Compound 4, distribution coefficient: 4.5
Beside the measured number, compound 4's estimate is 1.70 log units below it; measured number above the stated range.
By their numbers in this assay, from the lowest: compound 3; then compounds 2 and 1 (each within the scatter of the next); then compound 4.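

In this assay, among the compounds shown here, the substituent on this aromatic carbon, which lies between two ring nitrogen atoms, matters far more than the earlier compounds suggested: the change from methyl to cyclopropyl gives a number 2.20 log units higher from compound 3 to compound 4 (beyond the scatter). Cyclopropyl also stands apart from the other two groups, with a number 1.70 log units higher from compound 2 to compound 4 (beyond the scatter) and a number 1.60 log units higher from compound 1 to compound 4 (beyond the scatter), whereas the widest step among the earlier compounds was a number 0.60 log units lower from compound 1 to compound 3 (beyond the scatter). No measurement among these compounds gives a reason for a step of this size.

The compounds shown leave open whether this step goes with the three-membered ring itself or simply with the larger carbon count, and an open chain such as ethyl or isopropyl on the same carbon would separate the two. They also leave open how an amine or a methoxy group at this place would read in this assay, and whether a step of this size would recur with cyclopropyl in place of methyl on a different core.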